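This account rests on a few compounds, and the source may have more. Where it says the series, first, only, none or still open, it means among the compounds named here.

Two compounds measured in a functional assay on L1210 cells (Mus musculus), with a stated time of 12 days (on this read-out lower numbers stand for lower potency and higher numbers for higher potency (the scale is a negative logarithm)), share one core. Compound 1 `CC1=C(N2CC2)C(=O)C(C(C)COC(N)=O)=C(N2CC2)C1=O` gives 5.71. Compound 2 `CCC(OC)C1=C(N2CC2)C(=O)C(C)=C(N2CC2)C1=O` gives 5.33, the lower of the two numbers, with compound 1 the nearest to it. Among the compounds with values here, the one measured step, a number 0.38 log units lower from compound 1 to compound 2 (beyond the scatter), changed the same ring carbon that compound 3 `CC1=C(N2CC2)C(=O)C(N2CC2)=C(N2CC2)C1=O` alters again: aziridin-1-yl in place of 1-methoxypropyl on a double-bonded ring carbon. That step bears only loosely on the new change; the entering group differs from both earlier groups. A step of similar modest size, in either direction, is therefore expected, a number 0.27 log units higher from compound 2 to compound 3 (within the scatter). Compound 3 is estimated at 5.6, between 5 and 6.2.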

Compound 3, logarithm of the reciprocal of the active concentration, log(1/C): 6.21
Beside the measured number, compound 3's estimate is 0.61 log units below it; measured number outside the range, above it.
By their numbers in this assay, from the lowest: compound 2; then compound 1; then compound 3.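

At this double-bonded ring carbon in this assay, aziridin-1-yl in place of 1-methoxypropyl gives a number 0.88 log units higher from compound 2 to compound 3 (beyond the scatter), and in place of the open-chain group of compound 1 it gives a number 0.50 log units higher from compound 1 to compound 3 (beyond the scatter). So among these three compounds, the group with the fewest heavy atoms, and the only one with a ring, goes with the highest number at this position. Nothing available here explains that rise. The compounds shown leave open whether the three-membered ring matters or simply the shorter group. An open-chain dimethylamino group or a pyrrolidine ring at this carbon would help separate the two.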